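Ethylamino in place of a basic side chain on the core

The source may hold more compounds than are shown below. What is called first, only, known or untested is meant among the compounds shown, and "the series" means these compounds.

Compound 3 `Cc1ccc2c(NCc3ccc(NC(=O)C4CCN(Cc5ccccc5)CC4)cc3)nc(N3CCC(N4CCCC4)CC3)nc2c1` carries a 4-(pyrrolidin-1-yl)piperidin-1-yl group on an aromatic carbon of the shared core. In a functional assay on SV5A8 cells (Homo sapiens) for cytotoxicity (a lower number here means a stronger inhibitor, a higher number a weaker inhibitor), compound 3 gives > 8090 nM, which is a limit of the assay and not a number. The other two members of the set stand no differently. Compound 1 `COc1ccc(CN2CCC(C(=O)Nc3ccc(CNc4nc(N(C)C)nc5cc(C)ccc45)cc3)CC2)cc1` gives > 6180 nM in this assay, again a limit. Compound 2 `CCCCN1CCC(C(=O)Nc2ccc(CNc3nc(N(C)C)nc4cc(C)ccc34)cc2)CC1` gives > 10500 nM in this assay, also a limit. Going by the values given here, the only step among measured compounds, a step that the two limits leave unreadable from compound 1 to compound 2, is therefore unreadable, since both of its values sit at limits, namely the limit of > 6180 nM in this assay, at which 1 of the 3 values shown sits, and (the limit of > 10500 nM in this assay, at which 1 of the 3 values shown sits); compound 3 itself sits at the limit of > 8090 nM in this assay, at which 1 of the 3 values shown sits.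

Compound 4 `CCNc1nc(NCc2ccc(NC(=O)C3CCN(Cc4ccccc4)CC3)cc2)c2ccc(C)cc2n1` differs from compound 3 in one place: ethylamino in place of 4-(pyrrolidin-1-yl)piperidin-1-yl on an aromatic carbon. Among the compounds with values here, no measured step bears on this change, and the single step in the set concerns another part of the molecule and cannot be sized anyway. Within the data shown here, with every value so far a limit, there is no ground to expect a shift beyond the scatter in this assay. Compound 4 is expected to give 10000 nM, within 3000 nM to 35000 nM. The expected step that the limit leaves unreadable from compound 3 to compound 4 is estimated as none beyond the scatter, most likely again reported as a limit.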

Compound 4, half-maximal inhibitory concentration: > 2140 nM
Compound 4 ended at the assay's limit; the forecaster's own chance of this, stated with the estimate: 75%; the middle value does not contradict the limit.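

In this assay compound 4 gives > 2140 nM, which is a limit of the assay and not a number. Compound 3 also stands at a limit, so no step can be read from compound 3 to compound 4. The compounds shown leave open whether any change among them alters the response in this assay at all.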